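This account rests on a few compounds, and the source may have more. Where it says the series, first, only, none or still open, it means among the compounds named here.

Working notes on a small urea series. Compound 1 `C[C@@H](NC(=O)Nc1ccccc1F)c1ccccc1` and compound 2 `C[C@H](NC(=O)Nc1ccccc1F)c1ccccc1` share every atom and bond; (the two compounds have the same atoms and bonds and differ only in configuration as drawn: 1 of 1 stereo elements differ; a stereocentre at a saturated chain carbon is drawn S in compound 2 and R in compound 1). In an ADME assay on the whole organism with Oryza sativa as the target, tested at 10 uM (on this read-out higher numbers stand for a weaker effect at the one concentration tested and lower numbers for a stronger effect), compound 1 gives 77% and compound 2 gives 65%, so a number 12 percentage points lower from compound 1 to compound 2 (beyond the scatter), a difference that rests only on (the fact that compounds 1 and 2 differ only in the configuration as drawn). Compound 3 `C[C@H](NC(=O)Nc1cc(F)ccc1F)c1ccccc1` carries a single change from compound 2, (fluoro in place of hydrogen on an aromatic carbon); in this assay compound 3 gives 99%, which makes a number 34 percentage points higher from compound 2 to compound 3 (beyond the scatter). Compound 4 `C[C@@H](NC(=O)Nc1c(F)cccc1F)c1ccccc1` is not yet measured. It carries the same kind of change from compound 1, (fluoro in place of hydrogen on an aromatic carbon), but the surroundings differ: in compound 4 the fluoro sits ortho to a large group and meta to a fluoro group, whereas in compound 3 it sits meta to a large group and para to a fluoro group. Because a number 34 percentage points higher from compound 2 to compound 3 (beyond the scatter), a step in the same direction is expected for compound 4, a number 15 percentage points higher from compound 1 to compound 4 (beyond the scatter), set beside that earlier step, though the higher starting point of compound 1 leaves less room upward. Compound 4 is expected to give 92% in this assay, within 78% to 100%.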

Compound 4, a percentage reported as activity, at one concentration (the size of the read-out at that concentration, not a potency): 98%
Compound 4: the middle estimate sits 6 percentage points below what was measured, within the range that was stated.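

In this assay fluoro in place of hydrogen on an aromatic carbon gives a number 21 percentage points higher from compound 1 to compound 4 (beyond the scatter) and this step agrees with the earlier one on the other core: the same change on two cores in this assay, a number 34 percentage points higher (beyond the scatter) from compound 2 to compound 3 and a number 21 percentage points higher (beyond the scatter) from compound 1 to compound 4, 13 percentage points apart, within the scatter of two such steps. So the upward direction carries across these two cores, but that rests on one pair per core. The two steps differ both in the configuration as drawn and in the place of the fluoro, here ortho to a large group, so neither influence can be separated and nothing follows for any further core.

On these data alone, it remains open whether chloro, methoxy or trifluoromethyl in place of the hydrogen would shift the read-out in the same direction. As far as these compounds go, the effect of an ethyl in place of the methyl on the chain carbon is also open.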